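This account rests on a few compounds, and the source may have more. Where it says the series, first, only, none or still open, it means among the compounds named here.

Three compounds built on the shared core of compound 1 `C[C@H](Nc1cc(=O)oc2cc(OCc3ccccc3)ccc12)C(N)=O` have been measured in an assay for inhibition of Amine oxidase [flavin-containing] B (Rattus norvegicus); a lower number here means a stronger inhibitor, a higher number a weaker inhibitor. Compound 1 gives 680 nM. Compound 2 `NC(=O)[C@@H]1CCCN1c1cc(=O)oc2cc(OCc3ccccc3)ccc12` gives 16100 nM, and compound 3 `NC(=O)[C@@H]1CCCN1Cc1cc(=O)oc2cc(OCc3ccccc3)ccc12` gives 380 nM. Compound 3 has the lowest number of the three: one step is a 1.8-fold lower number from compound 1 to compound 3 (0.25 log units; within the scatter), and the other step is a 42-fold lower number from compound 2 to compound 3 (1.63 log units; beyond the scatter), so compound 3 cannot be set apart from compound 1, while it stands clearly apart from compound 2.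

Compound 4 `NC(=O)Cc1cc(=O)oc2cc(OCc3ccccc3)ccc12` is not yet measured. It differs from compound 3 by carbamoyl in place of 2-carbamoylpyrrolidin-1-yl on a saturated chain carbon bound to an aromatic carbon. For the measured compounds named here, the nearest measured step is the one from compound 1 to compound 3, where the part bearing the carbamoyl was rebuilt with a small effect, a 1.8-fold lower number from compound 1 to compound 3 (0.25 log units; within the scatter). The step of a 42-fold lower number from compound 2 to compound 3 (1.63 log units; beyond the scatter) shows that this region can matter a great deal, but it concerns the link to the ring rather than the ring itself. Going by the values given here, since no measured step removes the pyrrolidine ring, a modest shift in this assay toward a higher number is expected for compound 4, a 3.2-fold higher number from compound 3 to compound 4 (0.50 log units; beyond the scatter). Compound 4 is therefore estimated at 1200 nM, within a range from 300 nM to 5000 nM.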

Compound 4, half-maximal inhibitory concentration: 200 nM
For compound 4 the middle estimate is 6.0-fold (0.78 log units) above the measured one; measured number below the stated range.
By their numbers in this assay, from the lowest: compounds 4, 3 and 1 (each within the scatter of the next, the first and the last beyond it); then compound 2.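

In this assay, the pyrrolidine ring and its defined stereocentre prove dispensable: replacing 2-carbamoylpyrrolidin-1-yl with carbamoyl on the saturated chain carbon gives a 1.9-fold lower number from compound 3 to compound 4 (0.28 log units; within the scatter), so the two compounds cannot be set apart. Carbamoylmethyl on the aromatic carbon also separates from the other two linkages, with a 3.4-fold lower number from compound 1 to compound 4 (0.53 log units; beyond the scatter) against the amino-linked chain and an 81-fold lower number from compound 2 to compound 4 (1.91 log units; beyond the scatter) against the ring bound directly through its nitrogen. The data offer no evidence on why the ring can go without a measurable loss.

The compounds shown leave open whether the carbamoyl itself is needed, as a carboxylic acid or a nitrile in its place would test. As far as these compounds go, how a longer chain between the carbamoyl and the aromatic carbon would compare with carbamoylmethyl also remains open.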